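A few compounds are considered here, and "the series" means these few. Any claim that something is new, unique, unknown or untested is made for them only; others in the source may bear on it.

Measured so far:
compound 2, `COC(=O)c1cc(N)c(Nc2ccc(C#N)cc2)cc1Oc1c(C)cc(/C=C/C#N)cc1C`, 21.8 ug/mL
compound 1, `COCCOC(=O)c1cc(N)c(Nc2ccc(C#N)cc2)cc1Oc1c(C)cc(/C=C/C#N)cc1C`, 1.64 ug/mL

Among the measured compounds shown here, in a physicochemical assay for solubility, read by HPLC, with a stated time of 4 h, at pH 2 (a higher number here means a more soluble compound, a lower number a less soluble compound), compound 2 gives 21.8 ug/mL, the highest of the two numbers so far. Its nearest neighbour is compound 1, which gives 1.64 ug/mL. The unmeasured compound 3 is `Cc1cc(/C=C/C#N)cc(C)c1Oc1cc(Nc2ccc(C#N)cc2)c(N)cc1C(=O)OCCC#N`. It differs from compound 2 in one place: cyanomethyl in place of hydrogen on a saturated chain carbon bound to an oxygen next to a carbonyl group. For the measured compounds named here, one measured step bears on this change: a 13-fold higher number from compound 1 to compound 2 (1.12 log units; beyond the scatter). That step removed a short chain from the same place and raised the number by a large margin, so putting a chain back at that place is expected to move the number the other way. Since the entering group is not the same as the one that left, the expected size is taken as smaller than that step. For compound 3 the expected step is a 3.6-fold lower number from compound 2 to compound 3 (0.56 log units; beyond the scatter). Compound 3 is therefore estimated at 6 ug/mL, within a range from 2 ug/mL to 20 ug/mL.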

Compound 3, solubility: 0.94 ug/mL
For compound 3 the middle estimate is 6.4-fold (0.81 log units) above the measured one, outside the stated range (below it).
By their numbers in this assay, from the lowest: compounds 3 and 1 (each within the scatter of the next); then compound 2.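

Placing cyanomethyl on the saturated chain carbon bound to an oxygen next to a carbonyl group gives, in this assay, a 23-fold lower number from compound 2 to compound 3 (1.37 log units; beyond the scatter) and so the large drop at this place is no longer seen with methoxymethyl alone. Exchanging the methoxy at the end of that chain for cyano gives a 1.7-fold lower number from compound 1 to compound 3 (0.24 log units; within the scatter) and so these two chain ends cannot be told apart in this assay, while both chain-bearing compounds stand well under compound 2, the methoxycarbonyl compound. Nothing shown here explains why the number falls at this place.

The three compounds leave open whether the fall follows the added chain itself or what sits at its end. A plain ethyl group, or a chain ending in an amine or a carboxylic acid, would bear on that question.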